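This account rests on a few compounds, and the source may have more. Where it says the series, first, only, none or still open, it means among the compounds named here.

Going by the values given here, compound 1 `CN(C)CCn1cnnc1-c1cc(Oc2ccc(NC(=O)N/N=C/c3c[nH]c4ccccc34)cc2F)ccn1` gives 820 nM in a functional assay on A549 cells (Homo sapiens) for cytotoxicity, read by MTT assay, with a stated time of 72 h (a lower number here means a stronger inhibitor, a higher number a weaker inhibitor), numerically the lowest of the two values so far, though compound 2 `CN(C)CCn1cnnc1-c1cc(Oc2ccc(NC(=O)N/N=C/c3cc(C(C)(C)C)cc(C(C)(C)C)c3O)cc2F)ccn1`, which gives 980 nM in this assay, lies within the scatter of it, so the two cannot be ordered. Compound 3 `COc1ccc(/C=N/NC(=O)Nc2ccc(Oc3ccnc(-c4nncn4CCN(C)C)c3)c(F)c2)c(OC)c1OC` has not been measured; it differs from compound 1 by 2,3,4-trimethoxyphenyl in place of 1H-indol-3-yl on a carbon with a double bond to nitrogen. Among the compounds with values here, no measured pair shows a change of this kind, so its size is unknown; a step of modest size, in either direction or none beyond the scatter, is expected. Compound 3 is expected to give 1200 nM in this assay, between 400 nM and 4000 nM. The expected step is a 1.5-fold higher number from compound 1 to compound 3 (0.17 log units; within the scatter).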

Compound 3, half-maximal inhibitory concentration: 6680 nM
Compound 3: the middle estimate sits 5.6-fold (0.75 log units) below what was measured, outside the stated range (above it).
By their numbers in this assay, from the lowest: compounds 1 and 2 (each within the scatter of the next); then compound 3.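

In this assay, the carbon with a double bond to nitrogen proves sensitive to the group it carries: 2,3,4-trimethoxyphenyl in place of 1H-indol-3-yl gives an 8.1-fold higher number from compound 1 to compound 3 (0.91 log units; beyond the scatter), the first step readable at this place. Nothing available explains this difference. The whole group changes at once, so the compounds shown leave open whether the loss of the 1H-indol-3-yl or the arrival of the methoxy groups sets the step. A plain phenyl or a 1-methyl-1H-indol-3-yl at this place could separate the two.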